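A few compounds are considered here, and "the series" means these few. Any claim that something is new, unique, unknown or untested is made for them only; others in the source may bear on it.

Going by the values given here, compound 1 `COc1cccc2c1OCN(c1ccc3oc(-c4ccccc4)cc(=O)c3c1)C2` stands highest of the two numbers known in a functional assay on MCF7 cells (Homo sapiens) for inhibition, read by MTT assay, with a stated time of 48 h, tested at 7.5 ug/mL (a higher number here means more inhibition of growth at the concentration tested, a lower number less inhibition of growth), where compound 1 gives 32.5%. Its nearest neighbour, compound 2 `O=c1cc(-c2ccccc2)oc2ccc(N3COc4c(cccc4[N+](=O)[O-])C3)cc12`, gives 8.2%, and the step of a number 24.3 percentage points lower from compound 1 to compound 2 (beyond the scatter) lies beyond the scatter. Compound 3 `O=c1cc(-c2ccccc2)oc2ccc(N3COc4c(Br)cccc4C3)cc12` is given as "not active" (no number reported), with no number behind it. Compound 4 `COc1cc2c(c(OC)c1)OCN(c1ccc3oc(-c4ccccc4)cc(=O)c3c1)C2` differs from compound 1 by methoxy in place of hydrogen on an aromatic carbon. Among the compounds with values here, no measured step exchanges hydrogen for methoxy, so the steps from compound 1 to compound 2 and to compound 3, both replacements of the methoxy itself, bear on it only loosely. The step of a number 2.5 percentage points lower from compound 1 to compound 4 (within the scatter) is therefore expected to stay within the scatter, and compound 4 is estimated at 30%, within 12% to 48%.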

Compound 4, percent growth inhibition at one concentration: 48.9%
Beside the measured number, compound 4's estimate is 18.9 percentage points below it; measured number above the stated range.
By their numbers in this assay, from the lowest: compound 2; then compound 1; then compound 4.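

In this assay, methoxy in place of hydrogen on the aromatic carbon meta to the existing methoxy gives a number 16.4 percentage points higher from compound 1 to compound 4 (beyond the scatter). Going by these compounds alone, this shows that the position accepts a group and that growth inhibition rises beyond the scatter with this change, whereas the earlier compounds only replaced the existing methoxy and left this carbon unchanged. Nothing available explains the gain.

As far as these compounds go, whether an amine or a carboxylic acid on this same carbon would also raise inhibition stays open. So does whether a longer chain, such as ethoxy, would keep the gain seen with methoxy.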